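Aryl-triazole series on the shared core: cytotoxicity notes

The source may hold more compounds than are shown below. What is called first, only, known or untested is meant among the compounds shown, and "the series" means these compounds.

Measured so far in a functional assay on SW480 cells (Homo sapiens) for cytotoxicity, read by MTT assay, with a stated time of 4 days; a higher number here means a weaker inhibitor, a lower number a stronger inhibitor:
compound 1 `C=C1C[C@]23C[C@@]1(O)CC[C@@H]2c1cccc(C)c1[C@@H]3Cn1cc(-c2ccc(Br)cc2)nn1` reports only a limit, > 20000 nM.
compound 2 `C=C1C[C@]23C[C@@]1(O)CC[C@@H]2c1cccc(C)c1[C@@H]3Cn1cc(-c2ccc(F)cc2)nn1` reports only a limit, > 20000 nM.
compound 3 `C=C1C[C@]23C[C@@]1(O)CC[C@@H]2c1cccc(C)c1[C@@H]3Cn1cc(-c2ccc(C(F)(F)F)cc2)nn1` reports only a limit, > 20000 nM.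

Compound 3 therefore stands on no resolved number in this assay; its value is a limit, and the other two compounds also give limits, so no ordering among the three can be read. The steps between them, a step that the two limits leave unreadable from compound 1 to compound 3, a step that the two limits leave unreadable from compound 2 to compound 3 and a step that the two limits leave unreadable from compound 1 to compound 2, are all unreadable for the same reason, which is set out by the limit of > 20000 nM in this assay, at which 3 of the 3 values shown sit.

Compound 4 `C=C1C[C@]23C[C@@]1(O)CC[C@@H]2c1cccc(C)c1[C@@H]3Cn1cc(-c2ccc(C)cc2)nn1` is next; it differs from compound 3 as follows: methyl in place of trifluoromethyl on an aromatic carbon. The measured steps that bear on this change are the three exchanges at the same aromatic carbon, and none of them shows a readable size. There is thus no evidence of any effect of a substituent at that position within this series, and the step is expected to be a step that the limit leaves unreadable from compound 3 to compound 4, most likely again ending at the limit. For compound 4 in this assay the expected value is 30000 nM, with a range from 8000 nM to 100000 nM.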

Compound 4, half-maximal inhibitory concentration: > 20000 nM
Compound 4: a limit, no number; the forecaster's own chance of this, stated with the estimate: 85%; the middle value does not contradict the limit.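

Compound 4 also reports only a limit in this assay, so none of the steps linking compound 1, compound 2 and compound 3 to compound 4 can be read: the limit of > 20000 nM in this assay, at which 4 of the 4 values shown sit.

The compounds shown leave open how these four compounds rank against one another, and whether any substituent at this aromatic carbon gives a resolved number in this assay.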